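A few compounds are considered here, and "the series" means these few. Any claim that something is new, unique, unknown or untested is made for them only; others in the source may bear on it.

Measured in a functional assay on MDA-MB-231 cells (Homo sapiens) for inhibition, read by MTT assay, with a stated time of 48 h; on this read-out lower numbers stand for stronger inhibition and higher numbers for weaker inhibition:
Compound 1 `N#Cc1cccc(NC(=O)c2[nH]cnc2-c2nc3ccccc3[nH]2)c1`: 24900 nM
Compound 2 `O=C(NCC1CC1)c1[nH]cnc1-c1nc2ccccc2[nH]1`: 33100 nM

The value of compound 2 lies within the scatter of the value of compound 1, so the two cannot be ranked. Compound 3 `O=C(NC1CCC1)c1[nH]cnc1-c1nc2ccccc2[nH]1` places cyclobutyl in place of cyclopropylmethyl on an amide-type nitrogen. Going by the values given here, the only measured step that bears on this is a 1.3-fold higher number from compound 1 to compound 2 (0.12 log units; within the scatter), which changes the same amide-type nitrogen. One step is thin evidence, but it gives no reason to expect a shift beyond the scatter in this assay. The estimate is therefore a step of a 1.0-fold lower number from compound 2 to compound 3 (0.01 log units; within the scatter). Compound 3 is expected at 32000 nM, within an estimated range of 16000 nM to 62000 nM.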

Compound 3, half-maximal inhibitory concentration: 33800 nM
The estimate for compound 3 lay 1.1-fold (0.02 log units) below the measured number; the measured number falls inside the stated range.
By their numbers in this assay, from the lowest: compounds 1, 2 and 3 (each within the scatter of the next).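

In this assay, joining the same atoms as cyclobutyl rather than cyclopropylmethyl on the amide-type nitrogen gives a 1.0-fold higher number from compound 2 to compound 3 (0.01 log units; within the scatter), and replacing 3-cyanophenyl with cyclobutyl gives a 1.4-fold higher number from compound 1 to compound 3 (0.13 log units; within the scatter). All three groups tested at this position therefore remain unranked, whether the group is cyclobutyl, cyclopropylmethyl or 3-cyanophenyl. Nothing available explains this result. On these data alone, it remains open whether an amine, a carboxylic acid or a longer chain on this nitrogen would move the number beyond the scatter. Changes to the shared core also remain untested among these compounds.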